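Three Small Fused Cores With No Measurable Inhibition

The source may report more compounds than this note shows. Statements on the series, on what has been measured and on what is new or still open speak of the compounds shown alone.

Compound 1 `Cc1ncc2cnnc(S)n12`, compound 2 `Cc1nnc(S)n2cncc12` and compound 3 `Oc1nncc2cncn12` were each tested in a functional assay for inhibition, with Homo sapiens as the target; on this read-out higher numbers stand for weaker inhibition and lower numbers for stronger inhibition. For compound 1 the result is a limit of the assay, > 48000 nM. For compound 2 the result is likewise a limit, > 48000 nM. For compound 3 the result is again a limit, > 48000 nM. Compound 3 therefore stands where every measured value stands: the limit of > 48000 nM in this assay, at which 3 of the 3 values shown sit. Compound 4 `Sc1nncc2cncn12` is not yet measured and differs from compound 3 by sulfanyl in place of hydroxy on an aromatic carbon. Among the measured compounds shown here, no step between two measured compounds is available to guide the size of this change. Given (the limit of > 48000 nM in this assay, at which 3 of the 3 values shown sit), compound 4 is expected to stay at that limit, and the expected step that the limit leaves unreadable from compound 3 to compound 4 is none beyond the scatter. The estimate for compound 4 in this assay is 60000 nM, ranging from 20000 nM to 200000 nM.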

Compound 4, half-maximal inhibitory concentration: > 48000 nM
Compound 4 gave a limit, no number; the forecaster's own chance of this, stated with the estimate: 80%; the middle value is on the limit's open side.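

In this assay the steps from compound 1, compound 2 and compound 3 to compound 4 cannot be read, since each of these values is a limit: the limit of > 48000 nM in this assay, at which 4 of the 4 values shown sit.

The compounds shown leave open whether any change to this shared core gives a measurable inhibition.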